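A few compounds are considered here, and "the series" means these few. Any claim that something is new, unique, unknown or untested is made for them only; others in the source may bear on it.

Compound 1 `Cc1ccc(C2=NN(C(=S)Nc3ccccc3)C(c3ccc4c(c3)OCCO4)C2)cc1` gives 10300 nM in a functional assay on WM 266-4 cells (Homo sapiens) for antiproliferative activity, read by MTT assay, with a stated time of 48 h; on this read-out lower numbers stand for stronger inhibition of growth and higher numbers for weaker inhibition of growth.
Compound 2 `S=C(Nc1ccccc1)N1N=C(c2cccc(Cl)c2)CC1c1ccc2c(c1)OCCO2` gives > 200000 nM in this assay; this reading is a limit of the assay and not a number.

Compound 2 stands at the weak end of what has been measured: in this assay it sits at the limit of > 200000 nM in this assay, at which 1 of the 2 values shown sits, so only a range is known for it. Among the measured compounds shown here, the one measured step, an at least 19-fold higher number from compound 1 to compound 2 (1.28 log units; beyond the scatter), shows that the ring on the carbon with a double bond to nitrogen matters strongly, since swapping 4-methylphenyl for 3-chlorophenyl pushed the value past the limit.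

Compound 3 `COc1cccc(C2=NN(C(=S)Nc3ccccc3)C(c3ccc4c(c3)OCCO4)C2)c1` differs from compound 2 by methoxy in place of chloro on an aromatic carbon. For the measured compounds named here, no measured step exchanges one group for another at this same position, so the measured step bears on it only loosely: it tells how far the 3-substituted ring lies from the 4-methyl ring, not how methoxy compares with chloro. Compound 3 is therefore expected to stay weak, with a step of an at least 1.6-fold lower number from compound 2 to compound 3 (0.22 log units; that floor lies within the scatter) that is uncertain in direction. The estimate for compound 3 in this assay is 120000 nM, expected to lie between 20000 nM and 500000 nM.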

Compound 3, concentration for 50% growth inhibition: 1380 nM
Compound 3: middle estimate off by 87-fold (1.94 log units), on the high side; the measured number lies below the stated range.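

Exchanging 3-chlorophenyl for 3-methoxyphenyl in this assay brings an at least 140-fold lower number from compound 2 to compound 3 (2.16 log units; beyond the scatter), so a ring substituted as in compound 2 is not weak as such, and the group on that aromatic carbon decides much of the outcome. The earlier step could be read as a loss on leaving 4-methylphenyl, but a 7.5-fold lower number from compound 1 to compound 3 (0.87 log units; beyond the scatter) shows that another ring at this place can also give a lower number than the 4-methylphenyl ring does. The reading for compound 2 is a limit and not a number, so the full size of its step stays unknown: the limit of > 200000 nM in this assay, at which 1 of the 3 values shown sits.

The step from compound 1 changes both the group and where it sits on the ring, so the compounds shown do not separate these two changes. As far as these compounds go, how a hydroxy group, an amine or a longer chain such as ethoxy would fare at this place remains open, as does whether methoxy would give the same result on another carbon of the ring.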